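The source may hold more compounds than are shown below. What is called first, only, known or untested is meant among the compounds shown, and "the series" means these compounds.

Measured compounds: compound 1, `COc1ccc2c(OCc3nnc4sc(-c5cccn5C)nn34)ccnc2c1`, for which a functional assay on EBC-1 cells (Homo sapiens) for antiproliferative activity, with a stated time of 72 h (on this read-out lower numbers stand for stronger inhibition and higher numbers for weaker inhibition), records "not determined" (no result reported); compound 2, `COc1ccc(-c2nn3c(COc4ccnc5cc(OC)ccc45)nnc3s2)cc1`, with 161 nM in this assay.

Going by the values given here, compound 2 stands as the only compound with a number here, so nothing can be set beside it. Compound 3, `COc1ccc2c(OCc3nnc4sc(-c5ccc(F)cc5)nn34)ccnc2c1`, is not yet measured. It differs from compound 2 by fluoro in place of methoxy on an aromatic carbon. Among the compounds with values here, no step between measured compounds is at hand, so the size of this change can only be guessed; a step of modest size, within or close to the usual scatter, is expected, as a 1.2-fold higher number from compound 2 to compound 3 (0.09 log units; within the scatter). Compound 3 is therefore estimated at 200 nM in this assay, within a range of 70 nM to 600 nM.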

Compound 3, half-maximal inhibitory concentration: 187 nM
Compound 3: the middle estimate sits 1.1-fold (0.03 log units) above what was measured; measured number inside the range.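

Fluoro in place of methoxy on an aromatic carbon, para to a large group, gives a 1.2-fold higher number from compound 2 to compound 3 (0.07 log units; within the scatter) in this assay and so leaves the number at this position unchanged within the scatter. This first readable step shows that the 4-methoxyphenyl and 4-fluorophenyl compounds cannot be told apart on this read-out. No measurement at hand speaks to why this is so. On these data alone, whether an amine or a carboxylic acid at this position would give a similar number remains open. Compound 1 has no number, so its group cannot be compared.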